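Replacing a piperidine with a piperazine on a quinoline ether chain

The source may hold more compounds than are shown below. What is called first, only, known or untested is meant among the compounds shown, and "the series" means these compounds.

Measured compounds:
compound 1, `COc1cc2c(Oc3ccc(NC(=O)c4nn(-c5cccc(F)c5)c(=O)cc4C)cc3F)ccnc2cc1OCCCN1CCN(C)CC1`, 150 nM
compound 2, `COc1cc2c(Oc3ccc(NC(=O)c4nn(-c5ccc(Cl)cc5)c(=O)cc4C)cc3F)ccnc2cc1OCCCN1CCC(C)CC1`, 210 nM

Of the compounds shown here, two have been measured in a functional assay on A549 cells (Homo sapiens) for inhibition, read by MTT assay, with a stated time of 72 h; on this read-out lower numbers stand for stronger inhibition and higher numbers for weaker inhibition. Compound 1 gives 150 nM and compound 2 gives 210 nM; the two values lie within the scatter of each other, so the numbers do not separate them. Going by the values given here, the two compounds differ in more than one place, so no single step connects them.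

Compound 3, `COc1cc2c(Oc3ccc(NC(=O)c4nn(-c5ccc(Cl)cc5)c(=O)cc4C)cc3F)ccnc2cc1OCCCN1CCN(C)CC1`, has not yet been measured. It is derived from compound 2 by a single change: 4-methylpiperazin-1-yl in place of 4-methylpiperidin-1-yl on a saturated chain carbon, three bonds along the chain from an oxygen on an aromatic ring. The piperazine that enters is the same ring that compound 1 carries, and compound 1 gives 150 nM in this assay. On these two numbers alone, no step beyond the scatter is expected from compound 2 to compound 3, estimated as a 1.2-fold lower number from compound 2 to compound 3 (0.09 log units; within the scatter). Compound 3 is therefore expected to give about 170 nM, within a range from 80 nM to 360 nM.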

Compound 3, half-maximal inhibitory concentration: 270 nM
Estimate against measurement, compound 3: 1.6-fold (0.20 log units) below; the range from low to high includes it.
By their numbers in this assay, from the lowest: compounds 1, 2 and 3 (each within the scatter of the next).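

In this assay, the swap of 4-methylpiperidin-1-yl for 4-methylpiperazin-1-yl on this saturated chain carbon can now be read on its own, as a 1.3-fold higher number from compound 2 to compound 3 (0.11 log units; within the scatter), so the two rings are not separated at this position with the 4-chlorophenyl group in place. Compound 3 also gives a single-change link on the aromatic nitrogen, 4-chlorophenyl in place of 3-fluorophenyl, with a 1.8-fold higher number from compound 1 to compound 3 (0.26 log units; within the scatter), and that swap is not resolved either. Nothing shown gives a cause for either step.

As far as these compounds go, each change rests on a single pair of compounds, so it remains open whether the piperidine and piperazine would also stay within the scatter with the 3-fluorophenyl group. The compounds shown also leave open how a morpholine at the chain end, or a 2-(4-methylpiperazin-1-yl)ethyl chain, would read.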